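Removing one double bond from compound 2

The source may hold more compounds than are shown below. What is called first, only, known or untested is meant among the compounds shown, and "the series" means these compounds.

Measured so far in a functional assay on KETR3 cells (Homo sapiens) for inhibition, read by MTT assay, with a stated time of 120 h (on this read-out higher numbers stand for weaker inhibition and lower numbers for stronger inhibition), for three compounds:
- compound 1 `C/C(=C\c1ccc(NC(=O)Nc2ccc(Cl)c(C(F)(F)F)c2)cc1)C(=O)NC(C)c1ccccc1` gives > 50000 nM (a limit)
- compound 2 `O=C(/C=C/c1ccc(NC(=O)Nc2ccc(Cl)c(C(F)(F)F)c2)cc1)NC1CCC1` gives 17300 nM (a number)
- compound 3 `CC(NC(=O)c1cccc(-c2ccc(NC(=O)Nc3ccc(Cl)c(C(F)(F)F)c3)cc2)c1)c1ccccc1` gives 6460 nM (a number)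

For compound 1 the entry > 50000 nM is a limit of the assay, not a number. That leaves two real numbers to compare. Compound 2 at 17300 nM has the higher one, which means the weaker inhibition, and compound 3 at 6460 nM lies lower by a gap beyond the usual scatter.

The next compound to be tested is compound 4 `O=C(CCc1ccc(NC(=O)Nc2ccc(Cl)c(C(F)(F)F)c2)cc1)NC1CCC1`. It keeps the core of compound 2 and changes one group: 2-(cyclobutylcarbamoyl)ethyl stands in place of 2-(cyclobutylcarbamoyl)ethenyl on an aromatic carbon, para to a large group (2-(cyclobutylcarbamoyl)ethyl in place of 2-(cyclobutylcarbamoyl)ethenyl on an aromatic carbon). The cyclobutyl ring and the amide stay in the group.

Among the compounds with values here, no pair of measured compounds shows this change on its own, so the expectation rests on the closest relative, compound 2 at 17300 nM and on the modest size of the edit. In this assay the expected step of a 1.2-fold higher number from compound 2 to compound 4 (0.06 log units; within the scatter) lies within the usual scatter, with no firm direction. The estimate for compound 4 is 20000 nM (expected range 8000 nM to 50000 nM).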

Compound 4, half-maximal inhibitory concentration: > 50000 nM
Compound 4 was reported as a limit; the forecaster's own chance of this, stated with the estimate: 20%; middle value at least 2.5-fold (0.39 log units) away from the limit.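

In this assay compound 4 gives > 50000 nM, which is a limit of the assay and not a number. Replacing 2-(cyclobutylcarbamoyl)ethenyl with 2-(cyclobutylcarbamoyl)ethyl gives an at least 2.8-fold higher number from compound 2 to compound 4 (0.46 log units; beyond the scatter); this is the first step shown that isolates a single change, and it means that on this aromatic carbon the two groups are not interchangeable, even though they differ by only one double bond and keep the cyclobutyl ring and the amide. Only the lower bound of this loss is known, and its full size cannot be read, because compound 4 sits at a limit: the limit of > 50000 nM in this assay, at which 2 of the 4 values shown sit.

As far as these compounds go, this single step rests on the cyclobutyl amide alone, so it remains open whether the same change would have a similar effect with a different group on the amide nitrogen. The compounds shown also leave open how a chain with a carbon-carbon triple bond, a longer chain, or a carboxylic acid in place of the amide would behave at this position.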